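This account rests on a few compounds, and the source may have more. Where it says the series, first, only, none or still open, it means among the compounds named here.

In a functional assay on OVCAR-3 cells (Homo sapiens) for antiproliferative activity, read by WST assay, with a stated time of 72 h, in the absence of a further agent (on this read-out higher numbers stand for weaker inhibition and lower numbers for stronger inhibition), compound 1 (`CCCCCCCCCCc1c(C)c(CCCCCCCCCC)c2[n+](c1C)CCC2`) gives 600 nM and compound 2 (`CCCCCCCC/C=C/c1c(C)c(/C=C/CCCCCCCC)c2[n+](c1C)CCC2`) gives 800 nM, two values within the usual scatter of each other. Compound 3 (`CCCCCCCC/C=C\c1c(C)c(/C=C/CCCCCCCC)c2[n+](c1C)CCC2`) has not yet been measured. It has the same atoms and bonds as compound 2 and differs only in configuration as drawn (the two compounds have the same atoms and bonds and differ only in configuration as drawn: 1 of 2 stereo elements differ; a double bond is drawn E in compound 2 and Z in compound 3): a double bond is drawn E in compound 2 and Z in compound 3. For the measured compounds named here, no measured step of this kind is available, so no shift beyond the scatter is expected in this assay, in either direction. The expected step is no change at the digits printed from compound 2 to compound 3 (within the scatter). The estimated value for compound 3 is 800 nM, with an expected range from 350 nM to 1800 nM.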

Compound 3, half-maximal inhibitory concentration: 900 nM
Compound 3: the middle estimate sits 1.1-fold (0.05 log units) below what was measured; the range from low to high includes it.
By their numbers in this assay, from the lowest: compounds 1, 2 and 3 (each within the scatter of the next).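

In this assay the change gives a 1.1-fold higher number from compound 2 to compound 3 (0.05 log units; within the scatter), the first measured step of double-bond geometry among these compounds. Turning one of the two double bonds from E to Z therefore leaves the read-out within the scatter, and at this position the assay does not separate the two geometries. The comparison rests on a single difference: the fact that compounds 2 and 3 differ only in the configuration as drawn. The compounds shown leave open whether both double bonds drawn Z would behave the same way. They also leave open how a chain ending in an amine or a carboxylic acid would read here.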